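This account rests on a few compounds, and the source may have more. Where it says the series, first, only, none or still open, it means among the compounds named here.

Measured so far in a functional assay on HeLa cells (Homo sapiens) for inhibition, read by MTT assay, with a stated time of 48 h; on this read-out higher numbers stand for weaker inhibition and lower numbers for stronger inhibition:
compound 1 `COc1ccc(C(c2c[nH]c3ccc(Br)cc23)c2c[nH]c3ccc(Br)cc23)cc1` gives 5500 nM
compound 2 `COc1ccc(C(c2c[nH]c3ccc(Br)cc23)c2c[nH]c3ccc(Br)cc23)cc1OC` gives 6100 nM

Compound 2 has the higher of these two numbers, with compound 1 nearest; the step of a 1.1-fold higher number from compound 1 to compound 2 (0.04 log units; within the scatter) is within the scatter, so the two compounds are not separated. Compound 3 `Brc1ccc(C(c2c[nH]c3ccc(Br)cc23)c2c[nH]c3ccc(Br)cc23)cc1` differs from compound 2 by 4-bromophenyl in place of 3,4-dimethoxyphenyl on a saturated chain carbon bound to two aromatic carbons. Among the measured compounds shown here, the only measured step, a 1.1-fold higher number from compound 1 to compound 2 (0.04 log units; within the scatter), touched a different part of the molecule and stayed within the scatter, so no measured step bears directly on this change. Compound 3 is therefore expected to show a 1.1-fold lower number from compound 2 to compound 3 (0.02 log units; within the scatter), no step beyond the scatter. For compound 3 in this assay the estimate is 5800 nM, with a range from 2000 nM to 17000 nM.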

Compound 3, half-maximal inhibitory concentration: 1500 nM
The estimate for compound 3 lay 3.9-fold (0.59 log units) above the measured number, outside the stated range (below it).
By their numbers in this assay, from the lowest: compound 3; then compounds 1 and 2 (each within the scatter of the next).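

In this assay, the aromatic group on the saturated chain carbon bound to two aromatic carbons now proves able to shift the number: 4-bromophenyl in place of 3,4-dimethoxyphenyl gives a 4.1-fold lower number from compound 2 to compound 3 (0.61 log units; beyond the scatter), and bromo in place of methoxy on an aromatic carbon gives a 3.7-fold lower number from compound 1 to compound 3 (0.56 log units; beyond the scatter). Among the compounds shown here, the earlier methoxy step stayed within the scatter, so these are the first steps here to go beyond it. Nothing measured here says why the number falls.

The compounds shown leave open whether the lower number follows the bromo itself or the absence of methoxy. As far as these compounds go, how a chloro, an amine or a carboxylic acid in its place would read also stays open.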